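Cytotoxicity notes toward compound 4 in this series

The source may report more compounds than this note shows. Statements on the series, on what has been measured and on what is new or still open speak of the compounds shown alone.

Three members of the series have been read in an ADME assay on Vero cells (Chlorocebus sabaeus) for cytotoxicity, read by resazurin assay, with a stated time of 72 h; on this read-out higher numbers stand for lower toxicity in this test and lower numbers for higher toxicity in this test. Compound 1 `O=C(/C=C/c1ccc([N+](=O)[O-])o1)c1ccc(I)cc1` in this assay gives > 100000 nM, which is a limit of the assay and not a number. Compound 2 `CC(C)(C)c1ccc(C(=O)/C=C/c2ccc([N+](=O)[O-])o2)cc1` in this assay gives > 100000 nM, likewise a limit. Within the data shown here, compound 3 `CSc1ccc(C(=O)/C=C/c2ccc([N+](=O)[O-])o2)cc1` in this assay gives 40700 nM, the only actual number among the three values. The step from compound 1 to compound 2 cannot be read from the two limits (a step that the two limits leave unreadable from compound 1 to compound 2). The steps of an at least 2.4-fold lower number from compound 1 to compound 3 (0.39 log units; beyond the scatter) and an at least 2.4-fold lower number from compound 2 to compound 3 (0.39 log units; beyond the scatter) both point the same way, with the limit of > 100000 nM in this assay, at which 2 of the 3 values shown sit, setting the floor of how far they can be read.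

Compound 4 `O=C(/C=C/c1ccc([N+](=O)[O-])o1)c1ccc(-n2ccnc2)cc1` carries the change (1H-imidazol-1-yl in place of methylsulfanyl on an aromatic carbon). Among the measured compounds shown here, no measured step covers the 1H-imidazol-1-yl group itself; the two readable steps only show that methylsulfanyl sits lower than iodo and tert-butyl. Moving away from methylsulfanyl to another group is therefore expected to give a modest rise, a 1.8-fold higher number from compound 3 to compound 4 (0.27 log units; within the scatter), in this assay, with a fair chance of returning to the limit. For compound 4 the estimated value in this assay is 75000 nM, expected between 30000 nM and 200000 nM.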

Compound 4, half-maximal cytotoxic concentration: > 100000 nM
Compound 4: only a limit was reported; the forecaster's own chance of this, stated with the estimate: 40%; middle value at least 1.3-fold (0.12 log units) from the limit.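

In this assay, the new step, an at least 2.4-fold higher number from compound 3 to compound 4 (0.39 log units; beyond the scatter), shows that a five-membered aromatic ring with 2 hetero atoms can stand on this aromatic carbon without the lower number seen with methylsulfanyl, so the change to the shared core is not confined to iodo and tert-butyl. Among the four groups shown, only methylsulfanyl in compound 3 gives an actual number, and compound 3 is the one exception to an otherwise uniform reading at this position; the steps from compound 1 and compound 2 to compound 4 cannot be read, so iodo, tert-butyl and 1H-imidazol-1-yl cannot be placed in any order. The reading of this position is capped by a limit of the assay, which is not a number: the limit of > 100000 nM in this assay, at which 3 of the 4 values shown sit.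

As far as these compounds go, it remains open whether a methoxy group, a methylsulfonyl group or a dimethylamino group in the same place would give a number like that of compound 3 or would stay at the limit. From the compounds shown here alone, it also remains open whether the lower number goes with the sulfur atom itself or with the methylsulfanyl group as a whole, which an ethylsulfanyl group in this place could begin to separate.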